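Moving the Thiophene Attachment Point on a Shared Core

The compounds below may be only part of what the source reports. "The series", "measured", "known", "first", "only" and "open" are said of these compounds alone.

Three compounds share one core and differ only in where a hydroxyl sits on one of the two phenyl rings. In an assay on isolated protein for inhibition of DNA topoisomerase 1 (Homo sapiens), with a stated time of 30 min, tested at 20 uM (on this read-out higher numbers stand for a stronger effect at the one concentration tested and lower numbers for a weaker effect), compound 1 `Oc1cccc(-c2cc(-c3cccs3)cc(-c3ccccc3O)n2)c1` gives 1.5%, compound 2 `Oc1cccc(-c2cc(-c3cccs3)cc(-c3cccc(O)c3)n2)c1` gives 0%, and compound 3 `Oc1ccc(-c2cc(-c3cccs3)cc(-c3cccc(O)c3)n2)cc1` gives 1.1%. All three numbers are small. Compound 2 stands at the bottom of the three, yet a number 1.1 percentage points higher from compound 2 to compound 3 (within the scatter) and the reverse of a number 1.5 percentage points lower from compound 1 to compound 2 (within the scatter) both keep it within the scatter of its neighbours, so no real separation is seen among compounds 1, 2 and 3.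

Compound 4 `Oc1cccc(-c2cc(-c3ccsc3)cc(-c3cccc(O)c3)n2)c1` is built from compound 2 by a different kind of change: thiophen-3-yl in place of thiophen-2-yl on an aromatic carbon. For the measured compounds named here, none of the measured steps touches the thiophene, so no step bears directly on this change. The steps that exist, a number 1.5 percentage points lower from compound 1 to compound 2 (within the scatter), a number 0.4 percentage points lower from compound 1 to compound 3 (within the scatter) and a number 1.1 percentage points higher from compound 2 to compound 3 (within the scatter), all lie within the scatter, and the whole set sits near the floor of this assay. With nothing pointing to a move, the expectation for compound 4 is a step of a number 1 percentage points higher from compound 2 to compound 4 (within the scatter), that is, none beyond the scatter. Compound 4 is therefore estimated at 1%, with a range from 0% to 8% in this assay.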

Compound 4, a percentage reported as inhibition, at one concentration (the size of the read-out at that concentration, not a potency): 4.5%
Beside the measured number, compound 4's estimate is 3.5 percentage points below it; low and high end bracket the measured number.
By their numbers in this assay, from the lowest: compounds 2, 3, 1 and 4 (each within the scatter of the next).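

Replacing thiophen-2-yl with thiophen-3-yl, on the aromatic carbon opposite the ring nitrogen, is the first change shown at this position, and in this assay it gives a number 4.5 percentage points higher from compound 2 to compound 4 (within the scatter) with the hydroxyphenyl groups left as they are. The two groups have the same atoms and the same counts of donors and acceptors, so the only difference is where the thiophene is attached, and that difference produces no separation from compound 2 that stands clear of the usual variation between repeats. For the compounds shown here, this position therefore joins the hydroxyl positions in showing no real separation so far, although only this one pair speaks for it. Nothing measured here explains how this swap behaves. What a carboxylic acid, an amine or a longer chain would do at this position stays open, as the compounds shown carry only thiophen-2-yl and thiophen-3-yl there. Also open, on these data alone, is whether thiophen-3-yl would behave the same way with the other hydroxyl placements, since compound 1 and compound 3 appear here only with thiophen-2-yl.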